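The source may report more compounds than this note shows. Statements on the series, on what has been measured and on what is new or still open speak of the compounds shown alone.

In a functional assay on ECa-109 cells for inhibition, with ECa-109 cell line (Homo sapiens) as the target, read by sulforhodamine B assay (a lower number here means a stronger inhibitor, a higher number a weaker inhibitor), compound 1 (`O=C1C=C(Nc2ccccc2F)C(=O)c2c1nc1n2[C@H]2OC[C@@H](O)[C@H]2OC1`) gives 2760 nM and compound 2 (`Cc1ccc(NC2=CC(=O)c3nc4n(c3C2=O)[C@H]2OC[C@@H](O)[C@H]2OC4)cc1`) gives 3480 nM on the same core, while compound 3 (`O=C1C=C(Nc2ccc(I)cc2)C(=O)c2c1nc1n2[C@H]2OC[C@@H](O)[C@H]2OC1`) gives 2300 nM on it. Compound 3 thus stands level with the other two, since the steps to it (a 1.2-fold lower number from compound 1 to compound 3 (0.08 log units; within the scatter) and a 1.5-fold lower number from compound 2 to compound 3 (0.18 log units; within the scatter)) both lie within the scatter. The remaining step (a 1.3-fold higher number from compound 1 to compound 2 (0.10 log units; within the scatter)) lies within the scatter as well.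

Compound 4 (`O=C1C=C(N2CCCCC2)C(=O)c2c1nc1n2[C@H]2OC[C@@H](O)[C@H]2OC1`) has not yet been measured. It differs from compound 3 by piperidin-1-yl in place of (4-iodophenyl)amino on a double-bonded ring carbon. The measured steps bear on this change only in part. Going by the values given here, each swaps one substituted phenyl on the amine nitrogen for another, and no measured compound carries piperidin-1-yl, so the data offer no direct precedent. Since even the step of a 1.5-fold lower number from compound 2 to compound 3 (0.18 log units; within the scatter) stays within the scatter, no step beyond the scatter is expected in this assay in either direction, although this expectation is loose. The estimated step is a 1.3-fold higher number from compound 3 to compound 4 (0.12 log units; within the scatter) and is expected to remain small. In this assay compound 4 is estimated at 3000 nM with a range from 1000 nM to 9000 nM expected.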

Compound 4, half-maximal inhibitory concentration: > 8000 nM
Compound 4: only a limit was reported; the forecaster's own chance of this, stated with the estimate: 10%; middle value at least 2.6-fold (0.42 log units) away from the limit.
By their numbers in this assay, from the lowest: compounds 3, 1 and 2 (each within the scatter of the next). At a limit, above all of these: compound 4.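

Compound 4 is reported in this assay only as a limit: the limit of > 8000 nM in this assay, at which 1 of the 4 values shown sits. The three earlier compounds all carry a substituted phenyl on the amine nitrogen and showed no step beyond the scatter, so they left open whether this double-bonded ring carbon responds to any change at all. Replacing the whole arylamino group with piperidin-1-yl does register here, with an at least 3.4-fold higher number from compound 3 to compound 4 (0.54 log units; beyond the scatter) and with an at least 2.2-fold higher number from compound 2 to compound 4 (0.36 log units; beyond the scatter) and again with an at least 2.8-fold higher number from compound 1 to compound 4 (0.46 log units; beyond the scatter) in the same direction, so this position tolerates exchange of the phenyl substituents shown but not this replacement.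

The change removes the hydrogen-bond donor and the aromatic ring together, and the compounds shown cannot tell which of the two matters, nor how far compound 4 lies past its limit. A cyclohexylamino group, which keeps the amine hydrogen on a non-aromatic ring, or an N-methyl-N-phenylamino group, which keeps the aromatic ring without that hydrogen, would separate the two, and morpholin-4-yl would show whether other saturated rings behave like piperidin-1-yl.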